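This account rests on a few compounds, and the source may have more. Where it says the series, first, only, none or still open, it means among the compounds named here.

In a functional assay on HCT-116 cells (Homo sapiens) for inhibition, read by sulforhodamine B assay, with a stated time of 48 h, tested at 50 uM (a higher number here means more inhibition of growth at the concentration tested, a lower number less inhibition of growth), compound 1 `COc1cccc(/C=C/C(=O)/C=C/c2ccc(OCc3cn(CCOc4cc(=O)oc5ccccc45)nn3)c(OC)c2)c1` gives 70% and compound 2 `COc1cc(/C=C/C(=O)/C=C/c2cccs2)ccc1OCc1cn(CCCCCOc2cc(=O)oc3ccccc23)nn1` gives 31%. Compound 2 is the lower of the two numbers, and the gap between them lies beyond the scatter. Compound 3 `COc1cc(/C=C/C(=O)/C=C/c2ccccc2)ccc1OCc1cn(CCCCCOc2cc(=O)oc3ccccc23)nn1` differs from compound 2 by one change: phenyl in place of thiophen-2-yl on a double-bonded chain carbon bound to a double-bonded chain carbon, which puts phenyl in place of thiophen-2-yl on a double-bonded chain carbon bound to a double-bonded chain carbon. For the measured compounds named here, no measured pair shows this swap on its own. The expected change in this assay is small and not beyond the scatter, an estimated a number 4 percentage points higher from compound 2 to compound 3 (within the scatter). For compound 3, the estimated growth inhibition is 35%, with an expected range of 17% to 55%.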

Compound 3, percent growth inhibition at one concentration: 24%
Estimate against measurement, compound 3: 11 percentage points above, and the stated range covers the measured number.
By their numbers in this assay, from the lowest: compounds 3 and 2 (each within the scatter of the next); then compound 1.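

In this assay, exchanging the thiophen-2-yl group for a phenyl group gives a step (a number 7 percentage points lower from compound 2 to compound 3 (within the scatter)) that stays within the scatter. For the compounds shown here, this is the first single-change comparison at this position, and this assay does not separate the two rings there. Nothing available explains the result. Still open, as far as these compounds go, is whether a phenyl carrying an amine or a carboxylic acid at this place would move the number beyond the scatter. Compound 1 differs from compound 3 in more than one place, so no single change can be credited with its higher number.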